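Aryl swaps on the shared core: compound 2 to compound 3

This account rests on a few compounds, and the source may have more. Where it says the series, first, only, none or still open, it means among the compounds named here.

Measured in a functional assay on HeLa cells (Homo sapiens) for cytotoxicity, read by MTT assay, with a stated time of 48 h; on this read-out lower numbers stand for stronger inhibition and higher numbers for weaker inhibition:
- compound 1 `COc1cccc(OC)c1/C=C/[C@](C)(O)CC[C@@H]1[C@@]2(C)CCCC(C)(C)[C@@H]2CC[C@@]1(C)O`: 48200 nM
- compound 2 `CC(C)(C)c1ccc(/C=C/[C@](C)(O)CC[C@@H]2[C@@]3(C)CCCC(C)(C)[C@@H]3CC[C@@]2(C)O)cc1`: 48500 nM

Compound 2, at 48500 nM, cannot be separated from compound 1, so the two numbers give no order. Compound 3 `Cc1cccc(C)c1/C=C/[C@](C)(O)CC[C@@H]1[C@@]2(C)CCCC(C)(C)[C@@H]2CC[C@@]1(C)O` has not been measured. It carries 2,6-dimethylphenyl in place of 4-(tert-butyl)phenyl on a double-bonded chain carbon bound to a double-bonded chain carbon.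

Within the data shown here, only one measured step bears on this change: a 1.0-fold higher number from compound 1 to compound 2 (0.00 log units; within the scatter). It concerns the same place and stays within the scatter. One step is thin evidence, yet it gives no reason to expect a real shift in this assay. The estimated step is a 1.1-fold lower number from compound 2 to compound 3 (0.03 log units; within the scatter), which means none beyond the scatter. For compound 3 the estimate is 45000 nM, with an expected range from 25000 nM to 80000 nM.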

Compound 3, half-maximal inhibitory concentration: 3460 nM
Compound 3: middle estimate off by 13-fold (1.11 log units), on the high side; measured number outside the range, below it.
By their numbers in this assay, from the lowest: compound 3; then compounds 1 and 2 (each within the scatter of the next).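

In this assay this place on a double-bonded chain carbon bound to a double-bonded chain carbon proves able to shift the number: 2,6-dimethylphenyl in place of 4-(tert-butyl)phenyl gives a 14-fold lower number from compound 2 to compound 3 (1.15 log units; beyond the scatter) and 2,6-dimethylphenyl in place of 2,6-dimethoxyphenyl gives a 14-fold lower number from compound 1 to compound 3 (1.14 log units; beyond the scatter) as the matching step. The shared numbering in the two group names alone does not go with the lower number, since compound 1, with 2,6-dimethoxyphenyl, cannot be separated from compound 2. No measurement on hand accounts for the gap between the two 2,6-substituted groups.

On these data alone, whether both methyl groups of 2,6-dimethylphenyl are needed, or a single methyl group on the phenyl ring would give the same number, stays open. So does the outcome with 2,6-dichlorophenyl or with an amine on the phenyl ring at this place.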